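This account rests on a few compounds, and the source may have more. Where it says the series, first, only, none or still open, it means among the compounds named here.

Measured compounds in a functional assay for agonist activity at G protein-coupled receptor 88 (Homo sapiens), read by HTRF and cAMP accumulation; on this read-out higher numbers stand for an effect only at larger amounts of compound and lower numbers for an effect already at smaller amounts:
compound 1 `CC(C)C[C@H](N)CN(C(=O)[C@@H]1C[C@H]1c1ccccc1)c1ccc(-c2ccccc2)cc1`, 880 nM
compound 2 `O=C([C@@H]1C[C@H]1c1ccccc1)N(CC1CCCNC1)c1ccc(-c2ccccc2)cc1`, 10 nM
compound 3 `CC[C@H](C)[C@H](N)CN(C(=O)[C@@H]1C[C@H]1c1ccc(F)cc1F)c1ccc(-c2ccccc2)cc1`, 1300 nM

Compound 3 has the highest number of the three. Compound 1 comes nearest to it, and the two lie within the scatter of each other, while compound 2 lies far lower, beyond the scatter. Compound 4 `CC[C@H](C)[C@H](N)CN(C(=O)[C@@H]1C[C@H]1c1csc(C)n1)c1ccc(-c2ccccc2)cc1` differs from compound 3 in one place: 2-methyl-1,3-thiazol-4-yl in place of 2,4-difluorophenyl on a saturated ring carbon. For the measured compounds named here, the only step measured between two neighbours, an 88-fold lower number from compound 1 to compound 2 (1.94 log units; beyond the scatter), concerns the group on the saturated chain carbon bound to the amide-type nitrogen and says nothing about the group on the three-membered ring. Compounds 1 and 3 differ both in that chain group and in the group on the three-membered ring, so their closeness shows at most that those two changes together left the number within the scatter. Going by the values given here, no measured step bears on the exchange of 2,4-difluorophenyl for 2-methyl-1,3-thiazol-4-yl, and the expectation in this assay is therefore a step of no clear direction, a 1.2-fold higher number from compound 3 to compound 4 (0.06 log units; within the scatter), with wide uncertainty. Compound 4 is estimated at 1500 nM in this assay, with a range from 400 nM to 6000 nM.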

Compound 4, half-maximal effective concentration: 1500 nM
The estimate for compound 4 equals the measured number at the digits printed; measured number inside the range.
By their numbers in this assay, from the lowest: compound 2; then compounds 1, 3 and 4 (each within the scatter of the next).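

In this assay the exchange of 2,4-difluorophenyl for 2-methyl-1,3-thiazol-4-yl on a saturated ring carbon of the three-membered ring gives a 1.2-fold higher number from compound 3 to compound 4 (0.06 log units; within the scatter), the first step measured at this position. The two compounds lie within the scatter of each other even though a six-membered aromatic ring of carbon only gives way to a five-membered aromatic ring with 2 hetero atoms, and 2 hydrogen-bond acceptors enter where the leaving group has 0, so on this background the assay does not separate the two groups. No measured evidence is at hand that would explain why the two groups read alike.

On these data alone, whether a pyridin-3-yl group, a carboxylic acid or an unsubstituted thiophene ring on the same ring carbon would also fall within the scatter of these two compounds remains open. As far as these compounds go, it is also open whether 2-methyl-1,3-thiazol-4-yl would read the same alongside the piperidin-3-yl group, the chain change that gave an 88-fold lower number from compound 1 to compound 2 (1.94 log units; beyond the scatter).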